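Series notes: swapping the methylpiperazine of compound 3

The source may report more compounds than this note shows. Statements on the series, on what has been measured and on what is new or still open speak of the compounds shown alone.

Within the data shown here, compound 3 `Cc1cc(C)c(S(=O)(=O)N2CCC(N3CCN(C)CC3)CC2)c(C)c1` gives 1100 nM in a functional assay on DLD-1 cells (Homo sapiens) for antiproliferative activity, read by CellTiter-Glo, with a stated time of 72 h (on this read-out lower numbers stand for stronger inhibition and higher numbers for weaker inhibition), the highest of the three numbers so far. Compound 1 `Cc1cc(C)c(S(=O)(=O)N2CCC(N3CCC(CCO)CC3)CC2)c(C)c1` gives 19 nM in this assay, and compound 2 `Cc1cc(C)c(S(=O)(=O)N2CCC(N3CCC(C)CC3)CC2)c(C)c1` gives 0.03 nM in this assay; the gaps to compound 3 are a 58-fold higher number from compound 1 to compound 3 (1.76 log units; beyond the scatter) and a 37000-fold higher number from compound 2 to compound 3 (4.56 log units; beyond the scatter).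

Compound 4 `Cc1cc(C)c(S(=O)(=O)N2CCC(N3CCC(C(C)C)CC3)CC2)c(C)c1` alters compound 3 at the saturated ring carbon: 4-isopropylpiperidin-1-yl in place of 4-methylpiperazin-1-yl on a saturated ring carbon.

The step of a 37000-fold higher number from compound 2 to compound 3 (4.56 log units; beyond the scatter) is the direct precedent, now taken in the opposite direction but with an isopropyl rather than a methyl on the entering piperidine. The step of a 630-fold lower number from compound 1 to compound 2 (2.80 log units; beyond the scatter) shows that the group on that piperidine itself moves the number by a large amount, so the size of the isopropyl adds uncertainty. Because of a 37000-fold higher number from compound 2 to compound 3 (4.56 log units; beyond the scatter), a large step to a lower number is expected, a 3700-fold lower number from compound 3 to compound 4 (3.56 log units; beyond the scatter).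

Compound 4 is therefore estimated at 0.3 nM, within a range of 0.02 nM to 10 nM.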

Compound 4, half-maximal inhibitory concentration: 0.3 nM
The estimate for compound 4 equals the measured number at the digits printed; low and high end bracket the measured number.
By their numbers in this assay, from the lowest: compound 2; then compound 4; then compound 1; then compound 3.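

Compound 4 gives a second case of a 4-substituted piperidin-1-yl replacing 4-methylpiperazin-1-yl on this saturated ring carbon in this assay, and the number again falls sharply, with a 3700-fold lower number from compound 3 to compound 4 (3.56 log units; beyond the scatter) alongside the earlier step from compound 3 in the reverse sense to compound 2. The group carried by the piperidine also now has three members, with a 10-fold higher number from compound 2 to compound 4 (1.00 log units; beyond the scatter) for isopropyl in place of methyl and a 63-fold lower number from compound 1 to compound 4 (1.80 log units; beyond the scatter) for isopropyl in place of 2-hydroxyethyl, so isopropyl falls between the other two groups on this read-out. No measurement shown accounts for either change.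

The compounds shown leave open where a primary amine, a carboxylic acid or a longer alkyl chain on the piperidine would fall relative to these three groups. They also leave open whether the same order holds with any other sulfonyl group on the core.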